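From furan to nitrophenyl on the shared core

The source may hold more compounds than are shown below. What is called first, only, known or untested is meant among the compounds shown, and "the series" means these compounds.

Going by the values given here, in a functional assay on NCI-H460 cells (Homo sapiens) for inhibition, with a stated time of 72 h (on this read-out higher numbers stand for weaker inhibition and lower numbers for stronger inhibition), compound 2 `COc1ccc(S(=O)(=O)N2CCc3cccc(-c4ccco4)c32)cc1` gives 94.5 nM and holds the lower of the two numbers so far, while compound 1 `COc1ccc(S(=O)(=O)N2CCc3cccc(-c4ccc(N)cc4)c32)cc1` gives 288 nM and holds the higher. Compound 3 `COc1ccc(S(=O)(=O)N2CCc3cccc(-c4ccc([N+](=O)[O-])cc4)c32)cc1` carries 4-nitrophenyl in place of furan-2-yl on an aromatic carbon. Among the compounds with values here, the one measured step that bears on this is a 3.0-fold lower number from compound 1 to compound 2 (0.48 log units; beyond the scatter) with furan-2-yl replacing 4-aminophenyl. Compound 3 again has a six-membered aromatic ring of carbon only there, as compound 1 does. In this assay the expected move is a 2.8-fold higher number from compound 2 to compound 3 (0.44 log units; beyond the scatter) toward weaker inhibition, similar in size to the measured step and reversed in direction. The estimate for compound 3 is 260 nM with an expected range of 80 nM to 800 nM on this read-out.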

Compound 3, half-maximal inhibitory concentration: 53.1 nM
The estimate for compound 3 lay 4.9-fold (0.69 log units) above the measured number; measured number below the stated range.
By their numbers in this assay, from the lowest: compounds 3 and 2 (each within the scatter of the next); then compound 1.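

In this assay, 4-nitrophenyl in place of furan-2-yl gives a 1.8-fold lower number from compound 2 to compound 3 (0.25 log units; within the scatter), so a six-membered aromatic ring of carbon only can sit at this position without the weaker inhibition seen for compound 1. The group carried on that ring matters, as nitro in place of amino gives a 5.4-fold lower number from compound 1 to compound 3 (0.73 log units; beyond the scatter). No measurement available here explains this difference. Going by these compounds, whether a phenyl ring with no added group, or one carrying a carboxylic acid or a nitrile, would fall nearer compound 3 or compound 1 remains open.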